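Moving the methoxy group: what compound 3 may show

The source may hold more compounds than are shown below. What is called first, only, known or untested is meant among the compounds shown, and "the series" means these compounds.

Of the compounds shown here, two of a shared core have been measured in an ADME assay on Huh-7 cells (Homo sapiens) for cytotoxicity, read by MTT assay, with a stated time of 48 h; on this read-out lower numbers stand for higher toxicity in this test and higher numbers for lower toxicity in this test. Compound 1, `CN(C)CCCCN(C(=O)O)c1cccc(Cn2nc(-c3ccc(F)cc3)c3ccccc3c2=O)c1`, gives 8510 nM in this assay. Compound 2, `COc1ccc(-c2nn(Cc3ccc(NC(=O)OCCCCN(C)C)cc3)c(=O)c3ccccc23)cc1`, gives 20300 nM in this assay, the higher of the two numbers, and the gap to compound 1 lies beyond the scatter of repeated measurements. Among the compounds with values here, no pair of measured compounds differs in a single place, so no step between them can be isolated.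

Compound 3, `COc1ccccc1-c1nn(Cc2ccc(NC(=O)OCCCCN(C)C)cc2)c(=O)c2ccccc12`, has not yet been measured. It differs from compound 2 as follows: 2-methoxyphenyl in place of 4-methoxyphenyl on an aromatic carbon. The two compounds hold the same atoms, joined differently; only the position of the methoxy group on the aryl ring changes.

Within the data shown here, with no measured step of this kind to lean on, a change of this size is expected to stay within the scatter, with a step of a 1.1-fold lower number from compound 2 to compound 3 (0.05 log units; within the scatter), in no particular direction. Compound 3 is therefore estimated to give about 18000 nM in this assay, with a likely range from 8000 nM to 45000 nM.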

Compound 3, half-maximal cytotoxic concentration: 44800 nM
Estimate against measurement, compound 3: 2.5-fold (0.40 log units) below; measured number inside the range.
By their numbers in this assay, from the lowest: compound 1; then compound 2; then compound 3.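

In this assay, the place of the methoxy group on the aryl ring matters even with the same atoms: the change to 2-methoxyphenyl gives a 2.2-fold higher number from compound 2 to compound 3 (0.34 log units; beyond the scatter), a modest step that points to lower toxicity in this test. Within the data shown here, this is the first step in the set that can be read at a single place, and it shows that this aromatic carbon of the shared core carries a substituent whose arrangement alone can move the number beyond the scatter, although the two groups have identical counts of heavy atoms, hydrogen-bond donors and hydrogen-bond acceptors. Nothing at hand explains the direction or size of this step.

As far as these compounds go, it remains open whether a hydroxyl group, an ethoxy group or a chlorine atom in place of the methoxy group on the 2-methoxyphenyl ring would give a similar number, or whether a plain phenyl group would match either compound. A single pair also cannot say whether the step would persist with a shorter or longer amine chain on the other side of the molecule.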